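Moving a Trifluoromethyl Group on the Hydrazone Ring

The source may report more compounds than this note shows. Statements on the series, on what has been measured and on what is new or still open speak of the compounds shown alone.

Compound 2 `CN(C(=O)NC(=O)c1ccc(C(F)(F)F)cc1)c1nc(C(F)(F)F)c(C(=O)N/N=C/c2cccc(C(F)(F)F)c2)s1` is the anchor of this small set. In a functional assay on BCG823 cells (Homo sapiens) for inhibition, read by MTT assay, with a stated time of 72 h (on this read-out lower numbers stand for stronger inhibition and higher numbers for weaker inhibition), compound 2 gives 1.84 ug/mL. Compound 1 `CN(C(=O)NC(=O)c1ccc(C(F)(F)F)cc1)c1nc(C(F)(F)F)c(C(=O)N/N=C/c2ccc(C(F)(F)F)cc2)s1` differs from compound 2 by 4-(trifluoromethyl)phenyl in place of 3-(trifluoromethyl)phenyl on a carbon with a double bond to nitrogen. In this assay compound 1 reaches a limit of the assay, > 100 ug/mL, which is the situation recorded by the limit of > 100 ug/mL in this assay, at which 1 of the 3 values shown sits. The step of an at least 54-fold higher number from compound 2 to compound 1 (1.73 log units; beyond the scatter) is thus a loss whose full size cannot be read from the data.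

Compound 3 `CN(C(=O)NC(=O)c1ccccc1F)c1nc(C(F)(F)F)c(C(=O)N/N=C/c2cccc(C(F)(F)F)c2)s1` differs from compound 2 on the other side of the molecule, by 2-fluorophenyl in place of 4-(trifluoromethyl)phenyl on a carbonyl carbon. In this assay compound 3 gives 16.3 ug/mL, a loss shown by an 8.9-fold higher number from compound 2 to compound 3 (0.95 log units; beyond the scatter).

Compound 4 `CN(C(=O)NC(=O)c1ccccc1F)c1nc(C(F)(F)F)c(C(=O)N/N=C/c2ccc(C(F)(F)F)cc2)s1` has not yet been measured. It differs from compound 3 by 4-(trifluoromethyl)phenyl in place of 3-(trifluoromethyl)phenyl on a carbon with a double bond to nitrogen. The surroundings of the change are word for word the same as in the earlier pair, so this is the same change that turned compound 2 into compound 1. Within the data shown here, that single earlier step is the only guide available, and it was large. Compound 4 is expected to fall from compound 3 by a step of a 9.2-fold higher number from compound 3 to compound 4 (0.96 log units; beyond the scatter), an expectation resting on an at least 54-fold higher number from compound 2 to compound 1 (1.73 log units; beyond the scatter). Compound 4 is therefore estimated at 150 ug/mL, within a range from 40 ug/mL to 600 ug/mL, and it is quite likely that the assay will once more report only a limit rather than a number.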

Compound 4, half-maximal inhibitory concentration: 3.87 ug/mL
For compound 4 the middle estimate is 39-fold (1.59 log units) above the measured one; the whole stated range lies above it.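

In this assay, putting 4-(trifluoromethyl)phenyl in place of 3-(trifluoromethyl)phenyl brought a gain on the core of compound 3, a 4.2-fold lower number from compound 3 to compound 4 (0.62 log units; beyond the scatter), so the same change pointed in opposite directions on the two cores: the same change on two cores in this assay, an at least 54-fold higher number (1.73 log units; beyond the scatter) from compound 2 to compound 1 and a 4.2-fold lower number (0.62 log units; beyond the scatter) from compound 3 to compound 4, at least 220-fold (2.35 log units) apart, beyond the scatter of two such steps. The change on the carbonyl carbon, 2-fluorophenyl in place of 4-(trifluoromethyl)phenyl, also reversed its direction, with an at least 25-fold lower number from compound 1 to compound 4 (1.41 log units; beyond the scatter), which means that in these four compounds the result at one end of the molecule depends on what sits at the other end: the same change on two cores in this assay, an 8.9-fold higher number (0.95 log units; beyond the scatter) from compound 2 to compound 3 and an at least 25-fold lower number (1.41 log units; beyond the scatter) from compound 1 to compound 4, at least 220-fold (2.35 log units) apart, beyond the scatter of two such steps. Compound 1 is recorded only as a limit, so the full size of the steps that touch it stays unknown, and the four compounds show neither why the direction reverses nor which way the change would go on a third core: the limit of > 100 ug/mL in this assay, at which 1 of the 4 values shown sits.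

The compounds shown leave open whether the same reversal would appear with a plain phenyl or a longer chain on the carbonyl carbon. They also leave open how an amine or a carboxylic acid on the hydrazone ring would behave, so no general rule for this series can be drawn yet.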